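This account rests on a few compounds, and the source may have more. Where it says the series, first, only, none or still open, it means among the compounds named here.

Measured compounds in a toxicity assay on GES1 cells (Homo sapiens) for inhibition, read by MTT assay, with a stated time of 72 h; a lower number here means a stronger inhibitor, a higher number a weaker inhibitor:

Compound 1, `CCc1cc(N2CC[C@@H](C)[C@@H](N(C)c3ncnc4[nH]ccc34)C2)n2ncnc2n1`, gives > 100000 nM in this assay, which is a limit of the assay rather than a number.
Compound 2, `C=CCSc1nc2nc(C)cc(N3CC[C@@H](C)[C@@H](N(C)c4ncnc5[nH]ccc45)C3)n2n1`, gives > 100000 nM in this assay, again a limit and not a number.
Compound 3, `Cc1cc(N2CC[C@@H](C)[C@@H](N(C)c3ncnc4[nH]ccc34)C2)n2nc(SCCc3ccccc3)nc2n1`, gives 66200 nM in this assay.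

Compound 2 therefore stands at the limit, and only one other compound shown reaches a number, compound 3; the step of an at least 1.5-fold lower number from compound 2 to compound 3 (0.17 log units; that floor lies within the scatter) is the only measured step available, and its floor lies within the usual scatter. Compound 4, `Cc1cc(N2CC[C@@H](C)[C@@H](N(C)c3ncnc4[nH]ccc34)C2)n2nc(SCc3ccc(F)c(Cl)c3)nc2n1`, differs from compound 2 by 3-chloro-4-fluorophenyl in place of vinyl on a saturated chain carbon bound to a sulfur. Within the data shown here, the closest measured step is the one from compound 2 to compound 3, which also exchanged the vinyl for an aromatic ring on the same carbon, and it moved the number by no more than the scatter can account for. Compound 4 is thus expected to sit near the limit, with a step of an at least 1.4-fold lower number from compound 2 to compound 4 (0.15 log units; that floor lies within the scatter) that is small and may not be seen at all. The estimate for compound 4 in this assay is 70000 nM, within a range from 30000 nM to 150000 nM.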

Compound 4, half-maximal inhibitory concentration: > 100000 nM
Compound 4: no number, only a limit; the forecaster's own chance of this, stated with the estimate: 40%; middle value at least 1.4-fold (0.15 log units) from the limit.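

Placing an aromatic ring on the saturated chain carbon bound to a sulfur does not by itself give a readable number in this assay: compound 4 carries such a ring and still sits at a limit of the assay. Exchanging benzyl for 3-chloro-4-fluorophenyl gives an at least 1.5-fold higher number from compound 3 to compound 4 (0.17 log units; that floor lies within the scatter), so this change cannot be told from scatter, and the step from compound 2 to compound 4 cannot be read at all, as both of its ends are limits. Nearly everything here rests on the same ceiling of the read-out: the limit of > 100000 nM in this assay, at which 3 of the 4 values shown sit.

On these data alone, what stays open is whether any change at this position can lower the number clearly beyond the scatter. An amine or a carboxylic acid on this chain would be a further test of that.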